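Replacing the phenylpiperazine with bromine: an open question

The source may hold more compounds than are shown below. What is called first, only, known or untested is meant among the compounds shown, and "the series" means these compounds.

Going by the values given here, compound 2 `O=C(CN1CCN(c2ccccc2)CC1)Nc1ccc(C(=O)/C=C/c2cn(Cc3ccc(Br)cc3)nn2)cc1` gives 72400 nM in a functional assay on SK-N-SH cells (Homo sapiens) for inhibition, read by MTT assay (a higher number here means a weaker inhibitor, a lower number a stronger inhibitor), the higher of the two numbers measured so far, while compound 1 `O=C(CN1CCN(c2ccccc2F)CC1)Nc1ccc(C(=O)/C=C/c2cn(Cc3ccc(Br)cc3)nn2)cc1` gives 12800 nM. Among the compounds with values here, the only measured step, a 5.7-fold higher number from compound 1 to compound 2 (0.75 log units; beyond the scatter), concerns a change at a different part of the shared core. Compound 3 `O=C(CBr)Nc1ccc(C(=O)/C=C/c2cn(Cc3ccc(Br)cc3)nn2)cc1` differs from compound 2 by bromo in place of 4-phenylpiperazin-1-yl on a saturated chain carbon bound to a carbonyl carbon. Within the data shown here, no measured step bears on this change, so its size and direction rest on no data from this set. Compound 3 is therefore estimated at 10000 nM, with a wide range from 1500 nM to 70000 nM. This estimate means an expected step of a 7.2-fold lower number from compound 2 to compound 3 (0.86 log units; beyond the scatter), held with low confidence.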

Compound 3, half-maximal inhibitory concentration: 8300 nM
Beside the measured number, compound 3's estimate is 1.2-fold (0.08 log units) above it, within the range that was stated.
By their numbers in this assay, from the lowest: compounds 3 and 1 (each within the scatter of the next); then compound 2.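

In this assay, the 4-phenylpiperazin-1-yl group on this saturated chain carbon bound to a carbonyl carbon proves not to be required for a low number, with an 8.7-fold lower number from compound 2 to compound 3 (0.94 log units; beyond the scatter) when a single bromo takes its place. A group of 12 heavy atoms with two rings can thus give way to one atom here without the compound getting weaker. Nothing available explains this step. Still open, as far as these compounds go, is how a small amine such as dimethylamino, or a chloro, would read at this place, and so whether bromo itself matters.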